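Swapping the Aryl Group on a Pyrazoline Core

The source may report more compounds than this note shows. Statements on the series, on what has been measured and on what is new or still open speak of the compounds shown alone.

Of the compounds shown here, three that share a trimethoxyphenyl unit have been tested in a functional assay on BGC-823 cells (Homo sapiens) for antiproliferative activity, read by MTT assay, tested at 1 uM; a lower number here means a weaker effect, a higher number a stronger effect of the compound at the concentration tested. Compound 1 `COc1cc(C(=O)N/N=C/c2ccc(F)c(F)c2)cc(OC)c1OC` gives 33.1%, and compound 3 `COc1cc(C(=O)N/N=C/c2ccccc2C(F)(F)F)cc(OC)c1OC` gives 22.1%. Compound 2 `COc1cc(C2=NN(C(C)=O)C(c3c(Cl)cccc3Cl)O2)cc(OC)c1OC`, which carries its trimethoxyphenyl on a five-membered non-aromatic ring bearing an acetyl group, gives -1.4%. Compound 2 therefore stands lowest of the three numbers: compound 3 lies above it by a gap beyond the usual scatter, and compound 1 lies higher still, also beyond the scatter. In plain terms, compound 2 shows no measurable effect at the concentration tested.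

Going by the values given here, the next compound, compound 4 `COc1ccc(C2OC(c3cc(OC)c(OC)c(OC)c3)=NN2C(C)=O)c(OC)c1`, keeps the whole core of compound 2 and changes only one group: 2,4-dimethoxyphenyl in place of 2,6-dichlorophenyl on a saturated ring carbon.

Among the compounds with values here, no pair of measured compounds differs in just one place, so there is no measured step to lean on, and compounds 1 and 3 belong to a different core. Without a comparable precedent, the expected step in this assay is a number 9.4 percentage points higher from compound 2 to compound 4 (within the scatter), a modest rise that is not expected to go beyond the scatter. Compound 4 is accordingly estimated at 8%, with a range from -10% to 30%.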

Compound 4, a percentage reported as inhibition, at one concentration (the size of the read-out at that concentration, not a potency): 6.3%
For compound 4 the middle estimate is 1.7 percentage points above the measured one; measured number inside the range.
By their numbers in this assay, from the lowest: compounds 2 and 4 (each within the scatter of the next); then compound 3; then compound 1.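

Going by these compounds alone, this is the first measured step at the saturated ring carbon of the shared core: in this assay, 2,4-dimethoxyphenyl in place of 2,6-dichlorophenyl gives a number 7.7 percentage points higher from compound 2 to compound 4 (within the scatter) and so leaves the read-out unchanged. The entering group carries oxygen atoms and hydrogen-bond acceptors that the leaving group lacks, yet this exchange of one substituted phenyl ring for another does not separate compound 2 from compound 4 at the concentration tested. Nothing measured on these compounds tells why the read-out stays where it is.

From the compounds shown here alone, what remains open is whether this ring carbon responds to anything other than a substituted phenyl ring, for example a phenyl ring bearing a carboxylic acid or an amine, or a simple alkyl chain in its place, any of which might move the read-out or might not. Also open, going by these compounds, is what the acetyl group contributes, since it is the same in compound 2 and compound 4, and a longer chain in its place could be compared directly with either of them.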